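The source may hold more compounds than are shown below. What is called first, only, known or untested is meant among the compounds shown, and "the series" means these compounds.

Measured so far:
compound 1, `CC(C)[C@H](NC(=O)CN(c1nc(Cl)nc2[nH]cnc12)C1CC1)C(=O)OCc1ccccc1`: 51.3%
compound 2, `O=C(O)C[C@H](NC(=O)CN(c1nc(Cl)nc2[nH]cnc12)C1CC1)C(=O)O`: 25.1%

In a functional assay on the whole organism (Tail, strain ICR) with Mus musculus as the target, in the tail flick test, with a stated time of 90 min, at a dose of 25 umol/kg by the oral route (a lower number here means a weaker effect, a higher number a stronger effect of the compound at the dose given), compound 1 gives 51.3%, while compound 2 gives 25.1%, the lower of the two numbers, with compound 1 standing higher by a margin beyond the usual scatter. The two measured compounds differ in several places at once, so this gap cannot be tied to any single change.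

Compound 3, `N=C(N)NCCC[C@H](NC(=O)CN(c1nc(Cl)nc2[nH]cnc12)C1CC1)C(=O)O`, is not yet measured. Against compound 2 it differs in one place: a group of 6 heavy atoms (3 carbon, 3 nitrogen; no ring) in place of a group of 3 heavy atoms (1 carbon, 2 oxygen; no ring), on a saturated chain carbon, two bonds along the chain from an amide-type nitrogen and a carbonyl carbon. The second carboxy group of compound 2 is kept. Among the compounds with values here, no measured pair shows the effect of this particular exchange, so the direction rests on weak footing. In this assay the step is expected to be small, upward if anything, and likely within the scatter of repeated measurements. Compound 3 is therefore expected to give about 31%, between 12% and 52%. This corresponds to an expected step of a number 5.9 percentage points higher from compound 2 to compound 3 (within the scatter).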

Compound 3, a percentage reported as activity, at one dose (the size of the read-out at that dose, not a potency): 27.6%
Estimate against measurement, compound 3: 3.4 percentage points above; measured number inside the range.
By their numbers in this assay, from the lowest: compounds 2 and 3 (each within the scatter of the next); then compound 1.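

The step of a number 2.5 percentage points higher from compound 2 to compound 3 (within the scatter) in this assay comes from placing a group of 6 heavy atoms (3 carbon, 3 nitrogen; no ring) where the carboxy stood, on a saturated chain carbon, two bonds along the chain from an amide-type nitrogen and a carbonyl carbon. Within the data shown here, this is the first single-place comparison, and at this position the exchange produces no difference that can be told from scatter. No supporting data are available to explain this outcome.

On these data alone, whether a primary amine or a longer chain ending in a carboxylic acid at this position would give a step beyond the scatter remains open. Also open, as far as these compounds go, is how much of the gap to compound 1 belongs to its benzyl ester rather than to the other places in which it differs.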